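A few compounds are considered here, and "the series" means these few. Any claim that something is new, unique, unknown or untested is made for them only; others in the source may bear on it.

Working notes on the series. Compound 1 `Cc1c(F)c(N2CCC(N)C2)cc2c1c(=O)c(C(=O)O)cn2C1CC1` and compound 2 `NC1CCN(c2c(F)c(Cl)c3c(=O)c(C(=O)O)cn(C4CC4)c3c2Cl)C1` sit on two different cores; the difference between the two cores is not broken down here. In a functional assay on V79 cells (Cricetulus griseus) for cytotoxicity, read by colony formation (on this read-out lower numbers stand for stronger inhibition and higher numbers for weaker inhibition), compound 1 gives 14 ug/mL. For compound 2 this assay reports only a limit, > 500 ug/mL, and not a number. Compound 3 `CCNCC1CCN(c2cc3c(c(C)c2F)c(=O)c(C(=O)O)cn3C2CC2)C1` is obtained from compound 1 by the change ((ethylamino)methyl in place of amino on a saturated ring carbon), and in this assay compound 3 gives 42 ug/mL. The measured step for this change is a 3.0-fold higher number from compound 1 to compound 3 (0.48 log units; beyond the scatter).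

Compound 4 `CCNCC1CCN(c2c(F)c(Cl)c3c(=O)c(C(=O)O)cn(C4CC4)c3c2Cl)C1`, not yet measured in this assay, carries the same kind of change on the core of compound 2: (ethylamino)methyl in place of amino on a saturated ring carbon. Among the compounds with values here, the surroundings of the change read the same in both pairs, so the one measured instance is the closest guide available. Since the change moved the number up in the pair that was measured, and since compound 2 already sits at the limit of > 500 ug/mL in this assay, at which 1 of the 3 values shown sits, compound 4 is expected to come back as a limit of this assay as well rather than as a number. The expected step is a step that the limit leaves unreadable from compound 2 to compound 4, set beside the measured 3.0-fold higher number from compound 1 to compound 3 (0.48 log units; beyond the scatter). For compound 4 the estimate in this assay is 1200 ug/mL, with an expected range from 450 ug/mL to 3500 ug/mL, resting on the step from compound 1 to compound 3 and on the limit reported for compound 2.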

Compound 4, half-maximal inhibitory concentration: 270 ug/mL
The estimate for compound 4 lay 4.4-fold (0.65 log units) above the measured number; the whole stated range lies above it.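

Carried from the core of compound 1 to the core of compound 2, the change from amino to (ethylamino)methyl does not keep its direction in this assay: the same change on two cores in this assay, a 3.0-fold higher number (0.48 log units; beyond the scatter) from compound 1 to compound 3 and an at least 1.8-fold lower number (0.26 log units; that floor lies within the scatter) from compound 2 to compound 4, at least 5.5-fold (0.74 log units) apart, beyond the scatter of two such steps. Taken alone, the new step is an at least 1.8-fold lower number from compound 2 to compound 4 (0.26 log units; that floor lies within the scatter), and its full size cannot be read, with compound 2 standing only as a limit of the assay and not as a number. A step measured on one core is therefore a poor guide to the direction of this change on the other core, but with a single pair on each core the data show neither which difference between the cores goes with the reversal nor why it occurs.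

On these data alone, it remains open whether the result follows the ethyl group or the added carbon between the ring and the nitrogen, a question that plain aminomethyl and a longer chain such as (propylamino)methyl on the same saturated ring carbon of both cores would address. Also open, as far as these compounds go, is how a core carrying a single chlorine, with the methyl group kept, would respond to the same change from 3-aminopyrrolidin-1-yl to 3-((ethylamino)methyl)pyrrolidin-1-yl.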